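Thiophene Swap on Two Related Cores in Leukemia Cells

A few compounds are considered here, and "the series" means these few. Any claim that something is new, unique, unknown or untested is made for them only; others in the source may bear on it.

Measured in a functional assay on cells (Leukemia cell, Homo sapiens) for inhibition; on this read-out lower numbers stand for stronger inhibition of growth and higher numbers for weaker inhibition of growth:
compound 1 `N=C(N)N/N=C/c1c(-c2cccs2)nc2sccn12`: 6760 nM
compound 2 `Cc1cc(-c2nc3sccn3c2/C=N/NC(=N)N)c(C)s1`: 15500 nM
compound 3 `Cc1cc(-c2nc3n(c2/C=N/NC(=N)N)CCS3)c(C)s1`: 20900 nM

Within the data shown here, the one counted step is a 2.3-fold lower number from compound 2 to compound 1 (0.36 log units; beyond the scatter), brought about by thiophen-2-yl in place of 2,5-dimethylthiophen-3-yl on an aromatic carbon. Compound 3 and compound 2 share the same substituent but differ in their cores; that difference between the two cores is not broken down here, and their values lie within the scatter of each other. Compound 3 and compound 1 simply show a lower number for compound 1.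

Compound 4 `N=C(N)N/N=C/c1c(-c2cccs2)nc2n1CCS2` differs from compound 3 by thiophen-2-yl in place of 2,5-dimethylthiophen-3-yl on an aromatic carbon. This is the same kind of change as from compound 2 to compound 1, though here the place is also two ring bonds from two ring atoms that each bear a fused ring. For compound 4 the expected step is a 2.3-fold lower number from compound 3 to compound 4 (0.37 log units; beyond the scatter), resting on a 2.3-fold lower number from compound 2 to compound 1 (0.36 log units; beyond the scatter). Compound 4 is therefore estimated at 9000 nM, between 4000 nM and 20000 nM.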

Compound 4, concentration for 50% growth inhibition: 18600 nM
Compound 4: the middle estimate sits 2.1-fold (0.32 log units) below what was measured, within the range that was stated.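

In this assay, thiophen-2-yl in place of 2,5-dimethylthiophen-3-yl on the second core gives a 1.1-fold lower number from compound 3 to compound 4 (0.05 log units; within the scatter), so the change leaves no readable difference on that core. Set beside the step on the first core, this result does not differ from it by more than the scatter allows: the same change on two cores in this assay, a 2.3-fold lower number (0.36 log units; beyond the scatter) from compound 2 to compound 1 and a 1.1-fold lower number (0.05 log units; within the scatter) from compound 3 to compound 4, 2.0-fold (0.31 log units) apart, within the scatter of two such steps. The change therefore cannot be said either to carry over between the two cores or to fail to do so, since one pair on each core cannot settle whether the core alters its effect.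

The compounds shown leave open how other groups on this aromatic carbon, such as a phenyl ring or an amine, would behave on the two cores.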